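Shifting Fluorine Positions on the Cyclopropyl Aryl Group

This account rests on a few compounds, and the source may have more. Where it says the series, first, only, none or still open, it means among the compounds named here.

Three analogues sharing one amide core differ only in how fluorine is placed on the aryl ring attached to the cyclopropane. In a functional assay for agonist activity at G protein-coupled receptor 88 (Homo sapiens), read by HTRF and cAMP accumulation (on this read-out higher numbers stand for an effect only at larger amounts of compound and lower numbers for an effect already at smaller amounts), compound 1 `CC[C@H](C)[C@H](N)CN(C(=O)[C@@H]1C[C@H]1c1ccccc1F)c1ccc(-c2ccccc2)cc1` gives 650 nM. Compound 2 `CC[C@H](C)[C@H](N)CN(C(=O)[C@@H]1C[C@H]1c1cc(F)ccc1F)c1ccc(-c2ccccc2)cc1` gives 770 nM in this assay, and compound 3 `CC[C@H](C)[C@H](N)CN(C(=O)[C@@H]1C[C@H]1c1ccc(F)c(F)c1)c1ccc(-c2ccccc2)cc1` gives 720 nM. The steps between them are all small: a 1.2-fold higher number from compound 1 to compound 2 (0.07 log units; within the scatter), a 1.1-fold higher number from compound 1 to compound 3 (0.04 log units; within the scatter), and a 1.1-fold lower number from compound 2 to compound 3 (0.03 log units; within the scatter). Compound 3 therefore sits in the middle of the three numbers, separated from either neighbour by a gap that repeated measurement could erase.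

Compound 4 `CC[C@H](C)[C@H](N)CN(C(=O)[C@@H]1C[C@H]1c1c(F)cccc1F)c1ccc(-c2ccccc2)cc1` continues the same theme. The change is 2,6-difluorophenyl in place of 3,4-difluorophenyl on a saturated ring carbon; the two compounds hold the same atoms, joined differently, so only the arrangement of the two fluorines on that ring moves. Every measured rearrangement of fluorine on this ring, whether one fluorine or two, whether on one side of the ring or spread across it, has left the number where it was. On that evidence the expected step of no change at the digits printed from compound 3 to compound 4 (within the scatter) is none beyond the scatter, in no preferred direction. Among the compounds with values here, compound 4 is thus estimated at 720 nM, with a range from 350 nM to 1500 nM, acknowledging that no measured compound carries this particular fluorine pattern.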

Compound 4, half-maximal effective concentration: 11000 nM
Estimate against measurement, compound 4: 15-fold (1.18 log units) below; measured number outside the range, above it.
By their numbers in this assay, from the lowest: compounds 1, 3 and 2 (each within the scatter of the next); then compound 4.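

Fluorine placement on this aryl ring is therefore not neutral: in this assay, 2,6-difluorophenyl on the saturated ring carbon of the cyclopropane gives a 15-fold higher number from compound 3 to compound 4 (1.18 log units; beyond the scatter) in place of 3,4-difluorophenyl and a 14-fold higher number from compound 2 to compound 4 (1.15 log units; beyond the scatter) in place of 2,5-difluorophenyl, although the groups hold the same atoms. Adding one fluorine to the 2-fluorophenyl group is not harmless either: one placement gives a 17-fold higher number from compound 1 to compound 4 (1.23 log units; beyond the scatter) while the other gives a 1.2-fold higher number from compound 1 to compound 2 (0.07 log units; within the scatter) and stays within the scatter. What matters here is thus where the fluorines stand and not how many there are, and compounds 1, 2 and 3 go against any general penalty for fluorine on this ring, since only compound 4 shows the loss.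

Nothing shown explains why the number rises so sharply with this one arrangement. On these data alone, whether a chlorine or a methyl group in the two places held by fluorine in compound 4 would give the same rise, or would leave the number near that of compound 3, stays open.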